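Side-chain swap on the benzamide of compound 2

The source may hold more compounds than are shown below. What is called first, only, known or untested is meant among the compounds shown, and "the series" means these compounds.

Measured so far in a functional assay on MDA-MB-231 cells (Homo sapiens) for cytotoxicity, read by MTT assay, with a stated time of 96 h; a lower number here means a stronger inhibitor, a higher number a weaker inhibitor
Compound 1 `CC[C@H](N)C(=O)N[C@@H]1C(=O)N2[C@@H](CC[C@@H]1CCO)CC[C@H]2C(=O)NC(c1ccccc1)c1ccccc1` gives 1800 nM
Compound 2 `CC[C@H](N)C(=O)N[C@@H]1C(=O)N2[C@@H](CC[C@@H]1CCNC(=O)c1ccccc1)CC[C@H]2C(=O)NC(c1ccccc1)c1ccccc1` gives 930 nM
Compound 3 `CC[C@H](NC)C(=O)N[C@@H]1C(=O)N2[C@@H](CC[C@@H]1CCNC(=O)c1ccccc1)CC[C@H]2C(=O)NC(c1ccccc1)c1ccccc1` gives 210 nM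

Compound 2 gives 930 nM and so lies within the scatter of compound 1 and on the high side of compound 3. Compound 4 `CC[C@H](N)C(=O)N[C@@H]1C(=O)N2[C@@H](CC[C@@H]1CCNCc1ccccc1)CC[C@H]2C(=O)NC(c1ccccc1)c1ccccc1` keeps the shared core and puts benzyl in place of benzoyl on an amine nitrogen, turning 2-benzamidoethyl into 2-(benzylamino)ethyl.

Among the measured compounds shown here, the only measured step on this chain is hydroxy to benzamido (a 1.9-fold lower number from compound 1 to compound 2 (0.29 log units; within the scatter)), and it stayed within the scatter. The step that adds methyl on an amine nitrogen (a 4.4-fold lower number from compound 2 to compound 3 (0.65 log units; beyond the scatter)) is larger, but it lies at a different nitrogen and does not test this swap. For the measured compounds named here, no measured compound carries benzylamino, so the estimate stays wide. In this assay no step beyond the scatter is expected, and neither direction is favoured. The expected step is a 1.1-fold lower number from compound 2 to compound 4 (0.04 log units; within the scatter) and carries that same uncertainty. Compound 4 is estimated at 850 nM with an expected range of 280 nM to 2600 nM in this series.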

Compound 4, half-maximal inhibitory concentration: 400 nM
Compound 4: the middle estimate sits 2.1-fold (0.33 log units) above what was measured, and the stated range covers the measured number.
By their numbers in this assay, from the lowest: compounds 3 and 4 (each within the scatter of the next); then compounds 2 and 1 (each within the scatter of the next).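

In this assay the group on this amine nitrogen makes a difference: benzyl in place of benzoyl gives a 2.3-fold lower number from compound 2 to compound 4 (0.37 log units; beyond the scatter) on the 2-benzamidoethyl chain. Measured against hydroxy, benzylamino gives a 4.5-fold lower number from compound 1 to compound 4 (0.65 log units; beyond the scatter), whereas benzamido gave a 1.9-fold lower number from compound 1 to compound 2 (0.29 log units; within the scatter), so this position now shows a change that passes the scatter, which the earlier step on this chain did not. No measurement is available that accounts for the difference between benzyl and benzoyl here.

Going by these compounds, whether a longer chain such as 2-phenylethyl on this nitrogen, or a sulfonyl group in place of the benzoyl, would go further remains open. Also open, on these data alone, is whether methyl on an amine nitrogen, which gave a 4.4-fold lower number from compound 2 to compound 3 (0.65 log units; beyond the scatter), would add to the benzyl change in a single compound.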